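Ring methyl added to the core of compound 1

A few compounds are considered here, and "the series" means these few. Any claim that something is new, unique, unknown or untested is made for them only; others in the source may bear on it.

Compound 1 `Cc1nc(C)n2c(S)nncc12` in a functional assay for inhibition, with Homo sapiens as the target (on this read-out higher numbers stand for weaker inhibition and lower numbers for stronger inhibition), gives only a limit, > 48000 nM. Compound 2 `COCc1nc(C)c2cnnc(S)n12` likewise gives only a limit in this assay, > 48000 nM. For the measured compounds named here, the single measured step, a step that the two limits leave unreadable from compound 1 to compound 2, cannot be read in size because both values sit at the limit of > 48000 nM in this assay, at which 2 of the 2 values shown sit. Compound 3 `Cc1nnc(S)n2c(C)nc(C)c12` differs from compound 1 by methyl in place of hydrogen on an aromatic carbon. Going by the values given here, no readable step bears on this change, so no step in this assay can be expected beyond the scatter; the probable outcome is another limit. Compound 3 is estimated at 70000 nM, between 20000 nM and 250000 nM. Expected is a step that the limit leaves unreadable from compound 1 to compound 3, most likely reported again as a limit rather than a number.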

Compound 3, half-maximal inhibitory concentration: > 48000 nM
Compound 3 was reported as a limit; the forecaster's own chance of this, stated with the estimate: 85%; the middle value is on the limit's open side.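

No new step can be read between compound 1 and compound 3, because both stop at the same limit: the limit of > 48000 nM in this assay, at which 3 of the 3 values shown sit.

The compounds shown leave open whether any change to the shared core gives a readable number in this assay.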